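A few compounds are considered here, and "the series" means these few. Any claim that something is new, unique, unknown or untested is made for them only; others in the source may bear on it.

Compound 1, `C=CCOC(=O)C1=C(C)NC(C)=C(C(=O)OC)C1c1cccc([N+](=O)[O-])c1`, in a functional assay on HEK293 cells for antagonist activity at Voltage-dependent L-type calcium channel subunit alpha-1D (Rattus norvegicus), read by FLIPR; a lower number here means a stronger inhibitor, a higher number a weaker inhibitor: 15 nM
Compound 2, `C#CCCOC(=O)C1=C(C)NC(C)=C(C(=O)OC)C1c1cccc([N+](=O)[O-])c1`, in this assay: 35 nM

For the measured compounds named here, compound 2 holds the higher of the two numbers, and the only measured step, a 2.3-fold higher number from compound 1 to compound 2 (0.37 log units; beyond the scatter), is the one that separates it from compound 1. Compound 3, `C=C(C)CCOC(=O)C1=C(C)NC(C)=C(C(=O)OC)C1c1cccc([N+](=O)[O-])c1`, differs from compound 2 by 1-methylethenyl in place of ethynyl on a saturated chain carbon, two bonds along the chain from an oxygen next to a carbonyl group. Going by the values given here, that single step is the sole guide here: it moved the number modestly upward when an alkyne replaced an alkene, and compound 3 returns to an alkene, though a longer one carrying a methyl. The expected step is therefore small and downward, within the scatter: a 1.6-fold lower number from compound 2 to compound 3 (0.20 log units; within the scatter). Compound 3 is estimated at 22 nM, from 9 nM to 55 nM.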

Compound 3, half-maximal inhibitory concentration: 47 nM
Estimate against measurement, compound 3: 2.1-fold (0.33 log units) below; the measured number falls inside the stated range.
By their numbers in this assay, from the lowest: compound 1; then compounds 2 and 3 (each within the scatter of the next).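

In this assay, 1-methylethenyl in place of ethynyl gives a 1.3-fold higher number from compound 2 to compound 3 (0.13 log units; within the scatter) and so does not tell the two chain ends apart at this position. Measured from the vinyl end, a 3.1-fold higher number from compound 1 to compound 3 (0.50 log units; beyond the scatter) lies beyond the scatter, so an alkene at the chain end does not by itself bring compound 3 back to the number of compound 1. No measurement here gives a reason for either step.

Still open, from the compounds shown here alone, is whether the methyl or the chain length matters more, which a but-3-en-1-yl ester would separate. Going by these compounds, how an amine or a carboxylic acid at this chain end would read also remains unknown.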